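From but-1-en-1-yl to pent-1-en-1-yl in compound 4

This account rests on a few compounds, and the source may have more. Where it says the series, first, only, none or still open, it means among the compounds named here.

Compound 1 `C/C=C/c1ccccc1-c1cc2cn([C@H]3C[C@H](O)[C@@H](CO)O3)c(=O)nc2o1` gives 103000 nM
Compound 2 `CC/C=C/c1ccccc1-c1cc2cn([C@H]3C[C@H](O)[C@@H](CO)O3)c(=O)nc2o1` gives 102000 nM
Compound 3 `CC/C=C/c1ccc(-c2cc3cn([C@H]4C[C@H](O)[C@@H](CO)O4)c(=O)nc3o2)cc1` gives > 200000 nM (a limit of the assay)

In an ADME assay on HEL cells (Homo sapiens) for cytotoxicity (a lower number here means that less compound is tolerated, a higher number that more compound is tolerated), compound 2 gives 102000 nM and stands level with compound 1 within the scatter. For compound 3 the reading > 200000 nM is a limit of the assay and not a number.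

Compound 4 `CCC/C=C/c1ccccc1-c1cc2cn([C@H]3C[C@H](O)[C@@H](CO)O3)c(=O)nc2o1` has not yet been measured. It departs from compound 2 by a single change methyl in place of hydrogen on a saturated chain carbon, two bonds along the chain from a double-bonded chain carbon in the chain, which takes but-1-en-1-yl to pent-1-en-1-yl, with methyl in place of hydrogen on a saturated chain carbon, two bonds along the chain from a double-bonded chain carbon. Among the compounds with values here, one measured step bears on this: methyl in place of hydrogen on a saturated chain carbon bound to a double-bonded chain carbon, which came to a 1.0-fold lower number from compound 1 to compound 2 (0.00 log units; within the scatter) and so stayed small. Within the data shown here, with only that one step to go on, no shift beyond the scatter is expected in this assay for the further extension. The step expected is a 1.0-fold lower number from compound 2 to compound 4 (0.01 log units; within the scatter) by this estimate. For compound 4 the estimated value is 100000 nM with an expected range from 55000 nM to 175000 nM in this assay.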

Compound 4, half-maximal cytotoxic concentration: 41000 nM
Beside the measured number, compound 4's estimate is 2.4-fold (0.39 log units) above it; measured number below the stated range.
By their numbers in this assay, from the lowest: compound 4; then compounds 2 and 1 (each within the scatter of the next). At a limit, above all of these: compound 3.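

In this assay the earlier extension of the chain gave a 1.0-fold lower number from compound 1 to compound 2 (0.00 log units; within the scatter) and so suggested that this chain could grow without any consequence for the number. The next methyl, on a saturated chain carbon, two bonds along the chain from a double-bonded chain carbon, shows otherwise: it gives a 2.5-fold lower number from compound 2 to compound 4 (0.40 log units; beyond the scatter) and thus marks the first shift beyond the scatter among the chains compared here, with less compound tolerated carrying pent-1-en-1-yl than carrying but-1-en-1-yl. Taken from the shortest chain, the whole extension gives a 2.5-fold lower number from compound 1 to compound 4 (0.40 log units; beyond the scatter) and is of the same size, so across these three compounds the whole shift comes with the second added carbon and none with the first.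

From the compounds shown here alone, whether a longer chain such as hex-1-en-1-yl would lower the number again, or whether a chain carrying an amine would do the same, stays open. The values shown offer no measured reason for this step.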